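Trading 4-Aminophenyl for 3,4-Dichlorophenyl at a Carbonyl

A few compounds are considered here, and "the series" means these few. Any claim that something is new, unique, unknown or untested is made for them only; others in the source may bear on it.

Measured compounds:
compound 1 `COc1cc(-c2cc(/C=C/C(=O)c3ccc(N)cc3)[nH]n2)cc(OC)c1OC`: -76%
compound 2 `COc1ccc(-c2cc(/C=C/C(=O)c3ccc(OC)c(OC)c3)[nH]n2)cc1`: -100%

In a functional assay on Malme-3M cells (Homo sapiens) for cytotoxicity, read by sulforhodamine B assay, with a stated time of 48 h, tested at 100 uM (on this read-out higher numbers stand for a weaker effect at the one concentration tested and lower numbers for a stronger effect), compound 1 gives the highest of the two numbers, that is the weaker effect; the value of compound 2 lies a good way lower, beyond the scatter. Compound 3 `COc1cc(-c2cc(/C=C/C(=O)c3ccc(Cl)c(Cl)c3)[nH]n2)cc(OC)c1OC` has not been measured. It differs from compound 1 in one place: 3,4-dichlorophenyl in place of 4-aminophenyl on a carbonyl carbon. Among the compounds with values here, no measured pair shows this change, so its size is uncertain. The step of a number 12 percentage points lower from compound 1 to compound 3 (beyond the scatter) is expected to be of moderate size towards the stronger effect, with wide uncertainty. Compound 3 is estimated at -88%, between -100% and -60%.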

Compound 3, a percentage reported as activity, at one concentration (the size of the read-out at that concentration, not a potency): 24%
The estimate for compound 3 lay 112 percentage points below the measured number, and the stated range ends below it.
By their numbers in this assay, from the lowest: compound 2; then compound 1; then compound 3.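

In this assay the swap of 4-aminophenyl for 3,4-dichlorophenyl gives a number 100 percentage points higher from compound 1 to compound 3 (beyond the scatter) and so moves far towards the weaker effect. The group on this carbonyl carbon therefore matters greatly, since this one change, with the rest of compound 1 kept, is enough to shift the result this far. Nothing at hand explains the shift. As far as these compounds go, it remains open whether the outcome follows the loss of the amine or the arrival of the two chlorines. A plain phenyl or a phenyl carrying one chlorine at this place could separate those two possibilities.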